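The compounds below may be only part of what the source reports. "The series", "measured", "known", "first", "only" and "open" are said of these compounds alone.

In a physicochemical assay (a lower number here means that less compound is needed, a higher number that more compound is needed for the effect), compound 1 `COc1cc(/C=N/NC(=O)c2nn(-c3ccc(Cl)c(Cl)c3)c(-c3ccc(Cl)cc3)c2C)ccc1O` gives 2600000 nM, and compound 2 `COc1cc(/C=N/NC(=O)c2nn(-c3ccc(C(F)(F)F)cc3)c(-c3ccc(Cl)cc3)c2C)ccc1O` gives 2340000 nM. These two values lie within the usual scatter of each other, so compound 2 stands level with compound 1. Compound 3 `COc1cc(/C=N/NC(=O)c2nn(-c3ccc(C(F)(F)F)cc3)c(-c3ccc(Br)cc3)c2C)ccc1O` differs from compound 2 in one place: bromo in place of chloro on an aromatic carbon. In words, this is bromo in place of chloro on an aromatic carbon, turning 4-chlorophenyl into 4-bromophenyl. Among the compounds with values here, no measured step touches that group. Within the data shown here, the one measured step, a 1.1-fold lower number from compound 1 to compound 2 (0.05 log units; within the scatter), swaps 3,4-dichlorophenyl for 4-(trifluoromethyl)phenyl on an aromatic nitrogen, so it bears on the new change only indirectly. On that thin evidence, no step beyond the scatter is expected in this assay, in either direction. The expected step is a 1.0-fold lower number from compound 2 to compound 3 (0.01 log units; within the scatter). For compound 3 the estimated value is 2300000 nM, with an expected range from 1100000 nM to 4600000 nM.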

Compound 3, half-maximal effective concentration: 2910000 nM
Beside the measured number, compound 3's estimate is 1.3-fold (0.10 log units) below it, within the range that was stated.
By their numbers in this assay, from the lowest: compounds 2, 1 and 3 (each within the scatter of the next).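

Compound 3 is the first of these compounds to change the 4-chlorophenyl group: in this assay, bromo in place of chloro, para to a large group, gives a 1.2-fold higher number from compound 2 to compound 3 (0.09 log units; within the scatter) and so leaves the number level. This place therefore accepts this exchange of one halogen for another without a step beyond the scatter, at least with the 4-(trifluoromethyl)phenyl group present on the aromatic nitrogen. Nothing available explains why chloro and bromo read alike here.

The compounds shown leave open whether the number moves when something other than a halogen, such as an amine or a carboxylic acid, stands at this place on the aromatic ring. They also leave open whether bromo and chloro would still read alike with the 3,4-dichlorophenyl group on the aromatic nitrogen.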